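The compounds below may be only part of what the source reports. "The series", "measured", "known", "first", "only" and "open" are said of these compounds alone.

Compound 1 `COc1cc(C)cc(-c2c(-c3ccnc(-c4ccc(C(C)=O)cc4)c3)cnn2CC#N)c1` gives 4240 nM in a functional assay on CAKI-1 cells (Homo sapiens) for inhibition, read by sulforhodamine B assay, with a stated time of 48 h; a lower number here means a stronger inhibitor of growth, a higher number a weaker inhibitor of growth.
Compound 2 `COc1cc(C)cc(-c2nn(CC#N)cc2-c2ccc(-c3cccc(C(C)=O)c3)nc2)c1` gives 1910 nM in this assay.
Compound 3 `Cc1cc(O)cc(-c2nn(CC#N)cc2-c2ccnc(-c3ccc(N(C)C)cc3)c2)c1` gives 2890 nM in this assay.

Among these three numbers, compound 1 has the highest. Its nearest neighbour is compound 3, whose number is lower by an amount that stays within the scatter, so no order between compound 1 and compound 3 can be read from them. The furthest is compound 2, whose lower number lies beyond the scatter.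

Compound 4 `COc1cc(C)cc(-c2c(-c3ccnc(-c4ccc(N(C)C)cc4)c3)cnn2CC#N)c1` has not been measured. It arises from compound 1 by one change, (dimethylamino in place of acetyl on an aromatic carbon). Within the data shown here, no pair of measured compounds shows this step on its own, so its size is unknown. Compound 3 also carries a dimethylamino group on the same phenyl ring, and its number sits close to that of compound 1, while its other ring differs. The step from compound 1 to compound 4 is therefore expected to be small, at most a modest move toward a lower number, or none beyond the scatter: a 1.4-fold lower number from compound 1 to compound 4 (0.15 log units; within the scatter). Compound 4 is expected to give about 3000 nM, with a range from 1200 nM to 7500 nM.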

Compound 4, concentration for 50% growth inhibition: 36.9 nM
For compound 4 the middle estimate is 81-fold (1.91 log units) above the measured one, outside the stated range (below it).
By their numbers in this assay, from the lowest: compound 4; then compounds 2, 3 and 1 (each within the scatter of the next, the first and the last beyond it).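

Dimethylamino in place of acetyl, on an aromatic carbon para to a large group, gives a 110-fold lower number from compound 1 to compound 4 (2.06 log units; beyond the scatter) in this assay, although the two groups have the same count of heavy atoms and of hydrogen-bond acceptors. Among these compounds, the earlier compounds offered no step in a single place, so this is the first sign that the choice of group here can by itself shift growth inhibition far beyond the scatter; compound 3 carries the same 4-(dimethylamino)phenyl but differs from compound 4 elsewhere, so it cannot isolate this change. Nothing shown here accounts for the size of this step.

Going by these compounds, it remains open whether this shift is specific to dimethylamino or would extend to another amine, such as pyrrolidine or morpholine, or to a methoxy group at this position. Also open, on these data alone, is whether the same change would have a similar effect on the core of compound 2.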